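Notes on changing the amide substituent of compound 1

This account rests on a few compounds, and the source may have more. Where it says the series, first, only, none or still open, it means among the compounds named here.

Three measured compounds share one core bearing an unsaturated amide. Compound 1 `COc1cc2ncnc(N3CCc4ccccc43)c2cc1NC(=O)C=C(C)C` gives 7840 nM in a functional assay on PC-3 cells (Homo sapiens) for antiproliferative activity, read by MTT assay, with a stated time of 72 h; on this read-out higher numbers stand for weaker inhibition and lower numbers for stronger inhibition. Compound 2 `CC(C)=CC(=O)Nc1cc2c(N3CCc4ccccc43)ncnc2cc1O[C@@H]1CCOC1` carries an oxolan-3-yl in place of methyl on an oxygen on an aromatic ring and gives 4620 nM in this assay. That single change reads as a 1.7-fold lower number from compound 1 to compound 2 (0.23 log units; within the scatter). Compound 3 `CCC/C=C/C(=O)Nc1cc2c(N3CCCc4ccccc43)ncnc2cc1O[C@@H]1CCOC1` gives 11800 nM in this assay; it differs from compound 1 in more than one place, so only the two values themselves can be set side by side. Among the three numbers compound 1 stands second highest; its nearest neighbour is compound 3 and its furthest is compound 2, both within the scatter, so no order among the three can be read.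

Compound 4 `COc1cc2ncnc(N3CCc4ccccc43)c2cc1NC(=O)/C=C/CN1CCCC1` is not yet measured. It differs from compound 1 by 3-(pyrrolidin-1-yl)prop-1-en-1-yl in place of 2-methylprop-1-en-1-yl on a carbonyl carbon. Going by the values given here, no measured step touches this position: the one single-change step, from compound 1 to compound 2, concerns the oxygen substituent on the aromatic ring, and compound 3 changes two places at once. With nothing in the series speaking to the amide substituent, the step of a 1.1-fold lower number from compound 1 to compound 4 (0.05 log units; within the scatter) is expected to stay within the scatter, in either direction. Compound 4 is accordingly estimated at 7000 nM, with a range from 2000 nM to 25000 nM in this assay.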

Compound 4, half-maximal inhibitory concentration: 2620 nM
Estimate against measurement, compound 4: 2.7-fold (0.43 log units) above; measured number inside the range.
By their numbers in this assay, from the lowest: compounds 4, 2, 1 and 3 (each within the scatter of the next, the first and the last beyond it).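

Going by these compounds alone, the amide substituent is the first place where a single change moves the number beyond the scatter in this assay (a 3.0-fold lower number from compound 1 to compound 4 (0.48 log units; beyond the scatter)), while the only earlier single-change step, on the oxygen substituent, stayed within it (a 1.7-fold lower number from compound 1 to compound 2 (0.23 log units; within the scatter)). The position therefore accepts 3-(pyrrolidin-1-yl)prop-1-en-1-yl, with its five-membered non-aromatic ring and its nitrogen, in place of the all-carbon 2-methylprop-1-en-1-yl, and the number falls modestly instead of rising. Nothing available bears on why this step goes in this direction, so it stands as an observation on a single pair of compounds.

Open, on these data alone, is which part of the new substituent carries the step: the pyrrolidine ring, the nitrogen as such, or the chain that holds it, questions that a dimethylamino, piperidine or morpholine group on the same chain, or a plain carbocyclic ring without nitrogen, would begin to separate. Also open, as far as these compounds go, is whether the step holds when 3-(pyrrolidin-1-yl)prop-1-en-1-yl is paired with the oxolan-3-yl of compound 2 on the oxygen on the aromatic ring.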